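Naphthalene in Place of Chlorophenyl at the Sulfur

The source may hold more compounds than are shown below. What is called first, only, known or untested is meant among the compounds shown, and "the series" means these compounds.

Measured so far:
- compound 1, `Cc1cc(S(=O)(=O)/N=C(\N)n2nccc2-c2ccccc2)c(SCc2cccc(Cl)c2)cc1Cl`, gives 0.309 h in an ADME assay on microsomes from liver (Homo sapiens) for metabolic stability, read by LC-MS, using NADPH, tested at 5 uM; a higher number here means that the compound lasts longer, a lower number that the compound disappears faster
- compound 2, `Cc1cc(-c2ccccc2)n(/C(N)=N/S(=O)(=O)c2cc(C)c(Cl)cc2SCc2cccc(Cl)c2)n1`, gives 0.205 h in this assay
- compound 3, `Cc1cc(-c2ccccc2)n(/C(N)=N/S(=O)(=O)c2cc(C)c(Cl)cc2SCc2ccccc2C)n1`, gives 0.154 h in this assay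

The three compounds share one core and differ only in small groups at its edge. Compound 1 is the starting point here. The step of a 1.5-fold lower number from compound 1 to compound 2 (0.18 log units; within the scatter) and the step of a 1.3-fold lower number from compound 2 to compound 3 (0.12 log units; within the scatter) each stay within the usual scatter, and no step has been worked out between compound 1 and compound 3, which differ in two places; their two numbers stand as given above. So far, then, none of the three can be set apart from the others on this read-out.

Compound 4, `Cc1cc(S(=O)(=O)/N=C(\N)n2nccc2-c2ccccc2)c(SCc2cccc3ccccc23)cc1Cl`, has not been measured. Its change from compound 1 is naphthalen-1-yl in place of 3-chlorophenyl on a saturated chain carbon bound to a sulfur. For the measured compounds named here, the only measured step that touches the same place is a 1.3-fold lower number from compound 2 to compound 3 (0.12 log units; within the scatter), where a different group also replaced the 3-chlorophenyl on the saturated chain carbon bound to a sulfur, and that step stayed within the scatter. On this basis a step beyond the scatter is not expected in this assay, with a slight lean toward a lower number. Compound 4 is therefore estimated at 0.25 h, within a range from 0.12 h to 0.5 h, which would mean a 1.2-fold lower number from compound 1 to compound 4 (0.09 log units; within the scatter).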

Compound 4, half-life: 0.268 h
Estimate against measurement, compound 4: 1.1-fold (0.03 log units) below, within the range that was stated.
By their numbers in this assay, from the lowest: compounds 3, 2, 4 and 1 (each within the scatter of the next).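

In this assay, for the compounds shown here, the place on the saturated chain carbon bound to a sulfur accepts a much larger swap than the earlier compounds had tested, giving a 1.2-fold lower number from compound 1 to compound 4 (0.06 log units; within the scatter) even though naphthalen-1-yl brings 10 heavy atoms and 2 six-membered aromatic rings where 3-chlorophenyl had 7 heavy atoms, one such ring and a chlorine. Going by these compounds alone, until now the only change read at this place was the replacement by 2-methylphenyl, on the core of compound 2, so compound 4 adds a second replacement there, this time a group with an extra ring and on the core of compound 1, and it too stays within the scatter. Nothing measured here explains this result, so the read-out can only be recorded as it stands.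

As far as these compounds go, it remains open whether a group of another kind on this saturated chain carbon, such as a cyclohexyl ring, or an aromatic ring carrying an amine or a carboxylic acid, would move the half-life beyond the scatter. Also open, from the compounds shown here alone, is whether naphthalen-1-yl would behave the same way on the core of compound 2, which carries the extra methyl.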